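The source may hold more compounds than are shown below. What is called first, only, known or untested is meant among the compounds shown, and "the series" means these compounds.

Going by the values given here, in a functional assay on DU-145 cells (Homo sapiens) for inhibition, read by trypan blue exclusion, with a stated time of 72 h (on this read-out lower numbers stand for stronger inhibition and higher numbers for weaker inhibition), compound 1 `Cn1c(=O)c(S(=O)(=O)Cc2ccc(F)cc2F)cc2cnc(Nc3ccc4[nH]ccc4c3)nc21` gives 1000 nM and stands lowest of the three numbers so far. Compound 2 `Cn1c(=O)c(S(=O)(=O)c2ccc(F)cc2F)cc2cnc(Nc3ccc4occc4c3)nc21` gives 15000 nM and compound 3 `Cn1c(=O)c(S(=O)(=O)c2ccc(F)cc2F)cc2cnc(Nc3ccc4c(c3)CC(=O)N4)nc21` gives 100000 nM in the same test. The next analogue, compound 4 `Cn1c(=O)c(S(=O)(=O)c2ccc(O)cc2)cc2cnc(Nc3ccc4[nH]ccc4c3)nc21`, keeps the core of compound 1 and alters one group: 4-hydroxyphenyl in place of 2,4-difluorobenzyl on a sulfonyl sulfur with 4-hydroxyphenyl in place of 2,4-difluorobenzyl on a sulfonyl sulfur.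

Among the compounds with values here, the only measured step is a 6.7-fold higher number from compound 2 to compound 3 (0.82 log units; beyond the scatter) and it changes a group on a nitrogen on an aromatic ring, not the group on the sulfonyl sulfur. Within the data shown here, it gives a rough scale only, and no measured pair isolates the present change. Direction rests on weak evidence: compound 2 at 15000 nM and compound 3 at 100000 nM carry no 2,4-difluorobenzyl and both read higher than compound 1, though their other group differs too. A modest rise is therefore expected, and the estimated change is a 4.0-fold higher number from compound 1 to compound 4 (0.60 log units; beyond the scatter) with wide uncertainty. For compound 4 the estimate is 4000 nM with an expected range from 700 nM to 25000 nM at this stage.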

Compound 4, half-maximal inhibitory concentration: 250 nM
Estimate against measurement, compound 4: 16-fold (1.20 log units) above; the whole stated range lies above it.
By their numbers in this assay, from the lowest: compound 4; then compound 1; then compound 2; then compound 3.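

Going by these compounds alone, this is the first measured step at the sulfonyl sulfur: in this assay, 4-hydroxyphenyl in place of 2,4-difluorobenzyl gives a 4.0-fold lower number from compound 1 to compound 4 (0.60 log units; beyond the scatter) and leaves compound 4 with the lowest number of the four. The position therefore does not depend on 2,4-difluorobenzyl for activity in this test, and a group carrying a hydroxy and no fluorine is accepted there. The step changes the whole group at once, so it cannot assign the gain to the hydroxy, to the loss of fluorine or to the change from benzyl to phenyl, and no measurement offered here explains it.

Still open, from the compounds shown here alone, is whether the hydroxy itself is needed. A phenyl on the sulfonyl sulfur bearing a methoxy, an amine or a carboxylic acid in its place would test this.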